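Mirror Image of a Pyridyl Alcohol Antagonist

This account rests on a few compounds, and the source may have more. Where it says the series, first, only, none or still open, it means among the compounds named here.

Of the compounds shown here, two have been measured in an assay on HEK293 cells for antagonist activity at transient receptor potential cation channel subfamily V member 3 (Homo sapiens), read by FLIPR and calcium flux; on this read-out lower numbers stand for stronger inhibition and higher numbers for weaker inhibition. Compound 1, `C[C@@]1(c2ccc(OC(F)(F)F)cc2)C[C@@](O)(c2ccccn2)CO1`, gives 1120 nM in this assay, the higher of the two numbers. Compound 2, `O[C@H](c1ncccn1)C1(c2ccc(Cl)c(Cl)c2)CCC1`, gives 370 nM in this assay, a value beyond the scatter from that of compound 1; the two compounds share no single point of difference, so only their two values can be compared.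

Compound 3, `C[C@]1(c2ccc(OC(F)(F)F)cc2)C[C@](O)(c2ccccn2)CO1`, has not yet been measured. It differs from compound 1 as follows: the two compounds have the same atoms and bonds and differ only in configuration as drawn: 2 of 2 stereo elements differ (all stereocentres are inverted: mirror images); a stereocentre at a saturated ring carbon is drawn S in compound 1 and R in compound 3; a stereocentre at a saturated ring carbon is drawn R in compound 1 and S in compound 3. In words, the two compounds have the same atoms and bonds and differ only in configuration as drawn; all stereocentres are inverted, so the two are mirror images, one stereocentre at a saturated ring carbon being drawn S in compound 1 and R in compound 3, the other drawn R in compound 1 and S in compound 3.

Within the data shown here, no measured pair shows how such an inversion shifts this assay. A step of real size in either direction is possible, and the direction cannot be read from the data. For compound 3 the estimate is 900 nM, with a range from 150 nM to 5000 nM, which means an expected step of a 1.2-fold lower number from compound 1 to compound 3 (0.09 log units; within the scatter).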

Compound 3, antagonist equilibrium constant: 420 nM
Compound 3: the middle estimate sits 2.1-fold (0.33 log units) above what was measured; the range from low to high includes it.
By their numbers in this assay, from the lowest: compounds 2 and 3 (each within the scatter of the next); then compound 1.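

Among these compounds, until this result, no pair of compounds could be read in this assay, and nothing showed whether configuration matters on this core. The mirror-image change now gives a 2.7-fold lower number from compound 1 to compound 3 (0.43 log units; beyond the scatter) and so, although modest, the step shows that the two stereocentres taken together influence this read-out, with the configuration drawn in compound 3 giving the lower number. With no atom or bond changing, the step can be attributed to the arrangement at these stereocentres alone, because nothing else separates the pair: the fact that compounds 1 and 3 differ only in the configuration as drawn.

Both stereocentres invert together in this pair, and the compounds shown leave open whether one of them alone carries the step or both contribute. They also leave open whether the same preference between mirror images would hold on this core with an amine or a carboxylic acid attached.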